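Moving the methoxy group on the triazole-linked phenyl

A few compounds are considered here, and "the series" means these few. Any claim that something is new, unique, unknown or untested is made for them only; others in the source may bear on it.

Compound 1, `N#CC1=C(N)Oc2c(N)cc3nc4ccccc4nc3c2C12C(=O)N(Cc1cnnn1-c1ccccc1Cl)c1ccccc12`: in a functional assay on HCT-116 cells (Homo sapiens) for antiproliferative activity, read by MTT assay, with a stated time of 48 h (a higher number here means a weaker inhibitor, a lower number a stronger inhibitor), compound 1 gives only a limit, > 50000 nM.
Compound 2, `N#CC1=C(N)Oc2c(N)cc3nc4ccccc4nc3c2C12C(=O)N(Cc1cnnn1-c1cccc(C(F)(F)F)c1)c1ccccc12`: in this assay compound 2 gives 18900 nM.
Compound 3, `COc1ccc(-n2nncc2CN2C(=O)C3(C(C#N)=C(N)Oc4c(N)cc5nc6ccccc6nc5c43)c3ccccc32)cc1`: in this assay compound 3 gives only a limit, > 50000 nM.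

Compound 3 stands at the weak end of what has been measured. Its value is a limit, and it shares that limit with compound 1, as the limit of > 50000 nM in this assay, at which 2 of the 3 values shown sit, shows; only compound 2 gives an actual number.

Compound 4, `COc1ccccc1-n1nncc1CN1C(=O)C2(C(C#N)=C(N)Oc3c(N)cc4nc5ccccc5nc4c32)c2ccccc21`, keeps every atom of compound 3 and changes only where the methoxy group sits on the phenyl ring attached to the triazole: 2-methoxyphenyl in place of 4-methoxyphenyl on an aromatic nitrogen.

Within the data shown here, no measured step moves a methoxy group around this ring, so the nearest guidance is indirect. Going from the 2-chlorophenyl of compound 1 to the 3-(trifluoromethyl)phenyl of compound 2 gave an at least 2.6-fold lower number from compound 1 to compound 2 (0.42 log units; beyond the scatter), and going on to the 4-methoxyphenyl of compound 3 gave an at least 2.6-fold higher number from compound 2 to compound 3 (0.42 log units; beyond the scatter), returning to the limit. The step from compound 1 to compound 3 is unreadable, since both values are limits.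

With a group on a phenyl ring carrying a single substituent giving either a limit or a weak number in this assay, compound 4 is expected to remain weak, with a number no higher from compound 3 to compound 4 (the limit leaves the size open) as the expected step. Compound 4 is therefore estimated at 50000 nM, within 15000 nM to 150000 nM.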

Compound 4, half-maximal inhibitory concentration: > 50000 nM
Compound 4: only a limit was reported (the forecaster's own chance of this, stated with the estimate: 60%); the middle value sits exactly at the limit.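

Moving the methoxy group from the 4-methoxyphenyl of compound 3 to the 2-methoxyphenyl of compound 4 again gives only a limit in this assay, so neither of these two placements on the ring yields an actual number. The 3-(trifluoromethyl)phenyl group remains the only one here with an actual number, and swapping it for 2-methoxyphenyl gives an at least 2.6-fold higher number from compound 2 to compound 4 (0.42 log units; beyond the scatter). The steps among compound 1, compound 3 and compound 4 cannot be read, so any difference between the two methoxy placements stays hidden, and the new result simply adds one more compound at the same limit: the limit of > 50000 nM in this assay, at which 3 of the 4 values shown sit.

Going by these compounds, it remains open whether the lower number of compound 2 belongs to the trifluoromethyl group itself or to where that group sits on the ring. On these data alone, it is also open how an amine or a carboxylic acid on this phenyl ring, or a longer chain in place of the methoxy group, would read in this assay.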